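A few compounds are considered here, and "the series" means these few. Any claim that something is new, unique, unknown or untested is made for them only; others in the source may bear on it.

Measured in a functional assay on MCF7 cells (Homo sapiens) for cytotoxicity, read by MTT assay and propidium iodide staining, with a stated time of 24 h; on this read-out higher numbers stand for weaker inhibition and lower numbers for stronger inhibition:

- compound 1 `Cc1ccc(-c2nnc(SCC(=O)c3ccccc3)o2)c(O)c1` gives 150 nM
- compound 2 `COc1ccc(-c2nnc(SCC(=O)c3ccccc3)o2)c(O)c1` gives 280 nM

Only these two compounds have been measured, and their numbers lie within the usual scatter of each other, so compound 1 cannot be ranked above or below compound 2. The next compound to consider is compound 3 `Cc1ccc(-c2nnc(SCC(=O)c3ccc(Br)cc3)o2)c(O)c1`. It keeps the rest of compound 1 and turns phenyl into 4-bromophenyl, with bromo in place of hydrogen on an aromatic carbon, para to a large group (bromo in place of hydrogen on an aromatic carbon).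

Among the compounds with values here, the only measured step is methoxy in place of methyl on an aromatic carbon, and it comes to a 1.9-fold higher number from compound 1 to compound 2 (0.27 log units; within the scatter). That step lies within the scatter, but it changes a different group, so it says little about adding bromo. Within the data shown here, no measurement yet shows what any change at the phenyl does. The best expectation is therefore no step beyond the scatter in this assay, held with wide uncertainty. The expected change is no change at the digits printed from compound 1 to compound 3 (within the scatter). For compound 3 the estimated value is 150 nM, with an expected range from 40 nM to 500 nM.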

Compound 3, half-maximal inhibitory concentration: 2070 nM
For compound 3 the middle estimate is 14-fold (1.14 log units) below the measured one; measured number outside the range, above it.
By their numbers in this assay, from the lowest: compounds 1 and 2 (each within the scatter of the next); then compound 3.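

Bromo in place of hydrogen on an aromatic carbon, para to a large group, turns phenyl into 4-bromophenyl and gives a 14-fold higher number from compound 1 to compound 3 (1.14 log units; beyond the scatter) in this assay; on this read-out, that higher number means weaker inhibition. Within the data shown here, this is the first measured change at the phenyl, and it shows that adding one heavy atom there can matter, unlike the only earlier step, a 1.9-fold higher number from compound 1 to compound 2 (0.27 log units; within the scatter), which lies within the scatter and changes a different part of the molecule. No measured evidence here accounts for the loss seen with bromo.

A single compound cannot show whether this loss is specific to bromo or would also appear with another group at the same place, such as fluoro, an amine or a carboxylic acid. It also leaves open whether bromo at other carbons of the phenyl would give a similar number, and whether 4-bromophenyl would have a similar effect with methoxy in place of the methyl of compound 1.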